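From compound 2 to compound 3: one substituent exchanged

The compounds below may be only part of what the source reports. "The series", "measured", "known", "first", "only" and "open" are said of these compounds alone.

Measured in a physicochemical assay for solubility, read by chemiluminescence, in phosphate buffer, measured as kinetic solubility, at pH 7.4; a lower number here means a less soluble compound, a higher number a more soluble compound:
- compound 1 `Cc1cnc(Nc2ccc(C(=O)NCC3(c4nc(-c5ccccc5)cs4)CCOCC3)cc2)s1`: < 1000 nM (a limit)
- compound 2 `O=C(NCC1(c2nc(-c3ccccc3)cs2)CCOCC1)c1ccc(Nc2nc3ccccc3s2)cc1`: 4000 nM

Among the measured compounds shown here, compound 2 holds the only actual number so far, 4000 nM. Compound 1 gives only a limit.

Compound 3 `O=C(NCC1(c2nc(-c3ccccc3)cs2)CCOCC1)c1ccc(CN2CCCCC2)cc1` keeps the core of compound 2 and differs in one place: (piperidin-1-yl)methyl in place of (1,3-benzothiazol-2-yl)amino on an aromatic carbon. The group that leaves brings two aromatic rings with it, and the group that enters has a single non-aromatic ring.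

For the measured compounds named here, one measured step bears on this exchange: an at least 4.0-fold higher number from compound 1 to compound 2 (0.60 log units; beyond the scatter). That step lies beyond the scatter and was made within the group that now leaves, so this part of the molecule can clearly move the number in this assay. It is a single precedent, however, and it involves no group like the one entering. The structural change here is larger, so a rise beyond the scatter is expected, on the strength of the step to compound 2 with its an at least 4.0-fold higher number from compound 1 to compound 2 (0.60 log units; beyond the scatter).

The expected step is a 3.8-fold higher number from compound 2 to compound 3 (0.57 log units; beyond the scatter). The estimate for compound 3 is 15000 nM. The expected range for compound 3 runs from 3000 nM to 80000 nM.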

Compound 3, solubility: >= 396000 nM
Compound 3 ended at the assay's limit (the forecaster's own chance of this, stated with the estimate: 10%); middle value at least 26-fold (1.42 log units) from the limit.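

Among the compounds shown here, at this position, on an aromatic carbon para to a large group, the earlier compounds varied only the ring carried on the nitrogen, while replacing the whole group reaches much further in this assay: the change gives an at least 99-fold higher number from compound 2 to compound 3 (1.99 log units; beyond the scatter) and an at least 390-fold higher number from compound 1 to compound 3 (2.59 log units; beyond the scatter). Against compound 2, the entering (piperidin-1-yl)methyl has one six-membered non-aromatic ring and 0 hydrogen-bond donors where (1,3-benzothiazol-2-yl)amino has two aromatic rings and 1 hydrogen-bond donor, so several features change together and the step cannot be assigned to any one of them. Compound 3 gives a limit and not a number, so both steps remain open-ended: the limit of >= 396000 nM in this assay, at which 1 of the 3 values shown sits.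

The compounds shown leave open whether the nitrogen of the piperidine ring matters, which a cyclohexylmethyl group, with carbon in its place, or a morpholin-4-ylmethyl group, with a ring oxygen added, would help to separate. They also leave open whether the result depends on the methylene link, a question that a piperidin-1-yl group set directly on the aromatic carbon would address.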